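Amide acyl variation on the hexafluorocarbinol naphthylamide series

The compounds below may be only part of what the source reports. "The series", "measured", "known", "first", "only" and "open" are said of these compounds alone.

Measured so far:
compound 1, `CC(=O)Nc1c(C(O)(C(F)(F)F)C(F)(F)F)ccc2ccccc12`, 18 nM
compound 2, `CC(C)=CC(=O)Nc1c(C(O)(C(F)(F)F)C(F)(F)F)ccc2ccccc12`, 46 nM
compound 3, `O=C(Nc1c(C(O)(C(F)(F)F)C(F)(F)F)ccc2ccccc12)C1CCCC1`, 495 nM

In an assay on LtK cells with ATP-sensitive inward rectifier potassium channel 11 (Homo sapiens) as the target (a higher number here means that more compound is needed for the effect, a lower number that less compound is needed), compound 1 gives 18 nM, the lowest number of the three. Compound 2 follows, the step being a 2.6-fold higher number from compound 1 to compound 2 (0.41 log units; beyond the scatter). Compound 3, with 495 nM, stands highest in this assay: the steps of a 28-fold higher number from compound 1 to compound 3 (1.44 log units; beyond the scatter) and an 11-fold higher number from compound 2 to compound 3 (1.03 log units; beyond the scatter) both lie beyond the scatter.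

Compound 4, `O=C(CC1CCCC1)Nc1c(C(O)(C(F)(F)F)C(F)(F)F)ccc2ccccc12`, is not yet measured. It differs from compound 3 by cyclopentylmethyl in place of cyclopentyl on a carbonyl carbon. Every enlargement of the acyl group seen so far has raised the number in this assay, modestly for the alkenyl group and strongly for cyclopentyl. For the measured compounds named here, only three compounds carry that trend, and none tests a single added carbon directly, so the expected step is uncertain in size but leans upward: for compound 4 an estimated step of a 1.4-fold higher number from compound 3 to compound 4 (0.15 log units; within the scatter), possibly within the scatter. Compound 4 is therefore expected to give about 700 nM, with a range from 250 nM to 2000 nM.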

Compound 4, half-maximal effective concentration: 81 nM
Compound 4: middle estimate off by 8.6-fold (0.94 log units), on the high side, outside the stated range (below it).
By their numbers in this assay, from the lowest: compound 1; then compounds 2 and 4 (each within the scatter of the next); then compound 3.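

Cyclopentylmethyl in place of cyclopentyl on a carbonyl carbon gives, in this assay, a 6.1-fold lower number from compound 3 to compound 4 (0.79 log units; beyond the scatter), so enlarging the acyl group does not always raise the number, and compound 4 goes against the rise seen across compounds 1, 2 and 3. Cyclopentyl in place of hydrogen on a saturated chain carbon bound to a carbonyl carbon still gives a 4.5-fold higher number from compound 1 to compound 4 (0.65 log units; beyond the scatter), while the comparison with the alkenyl group gives a 1.8-fold higher number from compound 2 to compound 4 (0.25 log units; within the scatter), so among these compounds the count of carbons alone does not set the number. No measurement available here accounts for the shift.

Still open, going by these compounds, is whether a longer chain, such as cyclopentylethyl, would follow cyclopentylmethyl or return towards compound 3. Also open, on these data alone, is how an open-chain isobutyl group or an amine on the acyl chain would read in this assay.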